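Swapping a Methoxy for a Chlorine on the Benzamide

A few compounds are considered here, and "the series" means these few. Any claim that something is new, unique, unknown or untested is made for them only; others in the source may bear on it.

Of the compounds shown here, three have been tested in an assay on MDA-MB-231 cells for binding affinity to C-X-C chemokine receptor type 4 (Homo sapiens), read by immunofluorescence and microscopy, with stated times of 10 min and 30 min; on this read-out higher numbers stand for an effect only at larger amounts of compound and lower numbers for an effect already at smaller amounts. Compound 1 `Cc1ccc(S(=O)(=O)NCc2ccc(CNC(=O)c3ccccc3)cc2)cc1` carries a plain benzamide; in this assay compound 1 returns only the limit of > 1000 nM, not a number. Compound 2 `Cc1ccc(S(=O)(=O)NCc2ccc(CNC(=O)c3ccc([N+](=O)[O-])cc3)cc2)cc1` gives 10 nM. Compound 3 `COc1ccc(C(=O)NCc2ccc(CNS(=O)(=O)c3ccc(C)cc3)cc2)cc1` gives 100 nM, the highest of the two numbers measured; its nearest neighbour is compound 2, and the step of a 10-fold higher number from compound 2 to compound 3 (1.00 log units; beyond the scatter) lies beyond the scatter. Compound 1 sits at the limit (the limit of > 1000 nM in this assay, at which 1 of the 3 values shown sits).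

Compound 4 `Cc1ccc(S(=O)(=O)NCc2ccc(CNC(=O)c3ccccc3Cl)cc2)cc1` is the next step from compound 3: 2-chlorophenyl in place of 4-methoxyphenyl on a carbonyl carbon. Two measured steps speak to it. The step of an at least 10-fold lower number from compound 1 to compound 3 (1.00 log units; beyond the scatter) shows that adding the methoxy group pulled the number down from the limit; the step of an at least 100-fold lower number from compound 1 to compound 2 (2.00 log units; beyond the scatter) shows a nitro group did so even more. Among the measured compounds shown here, compound 4 gives up the methoxy group, and no measured compound carries a 2-chlorophenyl on the carbonyl carbon, so the chlorine's effect is unknown. The expectation is therefore a move back toward the limit, a higher number, with the step from compound 3 estimated as a 5.0-fold higher number from compound 3 to compound 4 (0.70 log units; beyond the scatter). Compound 4 is estimated at 500 nM, within a range from 100 nM to 3000 nM.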

Compound 4, effective concentration (reported as EC, without a stated level of effect): 10 nM
Beside the measured number, compound 4's estimate is 50-fold (1.70 log units) above it; measured number outside the range, below it.
By their numbers in this assay, from the lowest: compounds 2 and 4 (each within the scatter of the next); then compound 3. At a limit, above all of these: compound 1.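

Before compound 4, only the nitro group of compound 2 had given a number this low, but a 2-chlorophenyl on the carbonyl carbon shows that a second, different group can do so, with no change at the digits printed from compound 2 to compound 4 (within the scatter) in this assay. The change from 4-methoxyphenyl to 2-chlorophenyl gives a 10-fold lower number from compound 3 to compound 4 (1.00 log units; beyond the scatter), so the methoxy group is not needed for a low number at this position, and chloro in place of hydrogen alone is enough for an at least 100-fold lower number from compound 1 to compound 4 (2.00 log units; beyond the scatter). That last step gives only a minimum size and not an exact one, since compound 1 sits at a limit: the limit of > 1000 nM in this assay, at which 1 of the 4 values shown sits.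

Going by these compounds, what a 4-chlorophenyl or a 2-methoxyphenyl on the carbonyl carbon would give remains open, so the effect of the chlorine itself cannot yet be separated from the effect of where it sits on the aromatic ring. Also open, on these data alone, is how an amine or a carboxylic acid on that ring would read, and whether the similar numbers of compound 2 and compound 4 would hold for other groups at this position.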